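The source may report more compounds than this note shows. Statements on the series, on what has been measured and on what is new or still open speak of the compounds shown alone.

Measured in an in vitro assay on 293-EBNA cells for binding affinity to corticotropin-releasing factor receptor 1 (Homo sapiens); on this read-out higher numbers stand for weaker inhibition and lower numbers for stronger inhibition:
compound 1 `CCN(c1nc(C)nc2c1nnn2-c1ccc(C(C)C)cc1Br)C(COC)COC` gives 123 nM
compound 2 `COCC(C)(C)Nc1nc(C)nc2c1nnn2-c1ccc(C(C)C)cc1Br` gives 195 nM
compound 3 `COCCNc1nc(C)nc2c1nnn2-c1ccc(C(C)C)cc1Br` gives 242 nM

Compound 3 carries the highest of the three numbers, yet its steps to the other two, a 2.0-fold higher number from compound 1 to compound 3 (0.29 log units; within the scatter) and a 1.2-fold higher number from compound 2 to compound 3 (0.09 log units; within the scatter), both sit within the scatter, so the three are not separable. Compound 4 `CCC(COC)Oc1nc(C)nc2c1nnn2-c1ccc(C(C)C)cc1Br` differs from compound 3 by 1-(methoxymethyl)propoxy in place of (2-methoxyethyl)amino on an aromatic carbon. Within the data shown here, the three measured steps, a 1.6-fold higher number from compound 1 to compound 2 (0.20 log units; within the scatter), a 2.0-fold higher number from compound 1 to compound 3 (0.29 log units; within the scatter) and a 1.2-fold higher number from compound 2 to compound 3 (0.09 log units; within the scatter), each exchange one chain for another while the amino attachment stays; none trades the amino group for an alkoxy group, so no measured step bears directly on this change and no direction beyond the scatter can be argued. The estimate for compound 4 in this assay is therefore 300 nM with a wide range of 90 nM to 1200 nM, an expected step of a 1.2-fold higher number from compound 3 to compound 4 (0.09 log units; within the scatter).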

Compound 4, inhibition constant: 1.9 nM
Compound 4: the middle estimate sits 160-fold (2.20 log units) above what was measured, and the stated range ends above it.
By their numbers in this assay, from the lowest: compound 4; then compounds 1, 2 and 3 (each within the scatter of the next).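

In this assay the change on this aromatic carbon next to the ring nitrogen gives a 130-fold lower number from compound 3 to compound 4 (2.11 log units; beyond the scatter) and a 100-fold lower number from compound 2 to compound 4 (2.01 log units; beyond the scatter) and a 65-fold lower number from compound 1 to compound 4 (1.81 log units; beyond the scatter) with 1-(methoxymethyl)propoxy as the entering group. Chain exchanges that kept the amino attachment stayed within the scatter, while this alkoxy chain separates compound 4 from all three amino compounds. Nothing available accounts for the size of this gap.

Open is whether the oxygen itself or the chain carries the gain, since the same 1-(methoxymethyl)propyl chain on an amine nitrogen is absent from the compounds shown. On these data alone, a sulfur-linked version of this chain is equally open.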